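Growing the Group on the Saturated Ring Carbon

This account rests on a few compounds, and the source may have more. Where it says the series, first, only, none or still open, it means among the compounds named here.

Measured so far:
Compound 1, `COC(=O)[C@]1(C)N=C(c2ccccc2)N(Cc2ccccc2)[C@@H]1c1ccccc1`: 3000 nM
Compound 2, `COC(=O)[C@]1(C(C)C)N=C(c2ccccc2)N(Cc2ccccc2)[C@@H]1c1ccccc1`: 7100 nM

Both were tested in a functional assay on blood (Homo sapiens) for inhibition, read by ELISA, with stated times of 2 h and 18 h; on this read-out lower numbers stand for stronger inhibition and higher numbers for weaker inhibition. Among the compounds with values here, compound 2 stands with the higher of the two numbers, so its inhibition is the weaker of the pair; its only neighbour is compound 1, and the one measured step, a 2.4-fold higher number from compound 1 to compound 2 (0.37 log units; beyond the scatter), separates them. Compound 3, `COC(=O)[C@]1(Cc2ccccc2)N=C(c2ccccc2)N(Cc2ccccc2)[C@@H]1c1ccccc1`, is not yet measured. It differs from compound 2 in a single place: benzyl in place of isopropyl on a saturated ring carbon.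

Within the data shown here, only the step from compound 1 to compound 2 bears on this change, since it also exchanged the group on the same saturated ring carbon for one with more heavy atoms, and it gave a modest rise in the number. The new group again brings more heavy atoms, so a further rise of similar size is expected rather than a fall, though a single step is a thin basis and the aromatic ring is new to the series.

Compound 3 is therefore estimated at 12000 nM, with a likely range from 4000 nM to 36000 nM. The expected step is a 1.7-fold higher number from compound 2 to compound 3 (0.23 log units; within the scatter).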

Compound 3, half-maximal inhibitory concentration: 4100 nM
Estimate against measurement, compound 3: 2.9-fold (0.47 log units) above, within the range that was stated.
By their numbers in this assay, from the lowest: compounds 1, 3 and 2 (each within the scatter of the next, the first and the last beyond it).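

In this assay, the one rise seen so far (a 2.4-fold higher number from compound 1 to compound 2 (0.37 log units; beyond the scatter)) might have suggested that more heavy atoms on this saturated ring carbon always mean a higher number, but compound 3 goes against that idea, with benzyl bringing more heavy atoms than isopropyl and giving (a 1.7-fold lower number from compound 2 to compound 3 (0.24 log units; within the scatter)). The comparison with the smallest group in the set points the same way: phenyl in place of hydrogen on the saturated chain carbon gives (a 1.4-fold higher number from compound 1 to compound 3 (0.14 log units; within the scatter)), so a whole six-membered aromatic ring can be added here with no change that stands clear of the scatter, and heavy-atom count alone does not set the number at this position. Nothing measured here accounts for this result.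

The three groups shown are all plain hydrocarbons, which leaves open whether a group carrying an amine or a carboxylic acid on this carbon would stay in the same range of numbers. Also open, going by these compounds, is whether a longer chain, or a phenethyl group that sets the aromatic ring further from the core, would behave like benzyl or like isopropyl.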